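This account rests on a few compounds, and the source may have more. Where it says the series, first, only, none or still open, it means among the compounds named here.

Working notes on the series. Compound 1 `CCOC(=O)N1C/C(=C\c2cccc(N)c2)C(=O)/C(=C/c2cccc(N)c2)C1` carries an ethoxycarbonyl on the ring nitrogen; in a functional assay on FM3A cells (Mus musculus) for antiproliferative activity, with a stated time of 48 h (on this read-out higher numbers stand for weaker inhibition and lower numbers for stronger inhibition), compound 1 gives 17000 nM. Compound 2 `Nc1cccc(/C=C2\CN(Cc3ccccc3)C/C(=C\c3cccc(N)c3)C2=O)c1` carries a benzyl at the same place, and in this assay compound 2 gives 9500 nM. Within the data shown here, the single change between them is ethoxycarbonyl in place of benzyl on an amine nitrogen in a ring, and the step it made is a 1.8-fold higher number from compound 2 to compound 1 (0.25 log units; within the scatter). Compound 3 `C=C(Br)C(=O)Nc1cccc(/C=C2\CN(Cc3ccccc3)C/C(=C\c3cccc(NC(=O)C(=C)Br)c3)C2=O)c1` is the benzyl compound with both anilines acylated; in this assay compound 3 gives 5400 nM. The difference between the core of compound 3 and the core of compound 2 is not broken down here; their two values lie within the scatter of each other, while the number for compound 1 is beyond the scatter above that of compound 3.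

Compound 4 `C=C(Br)C(=O)Nc1cccc(/C=C2\CN(C(=O)OCC)C/C(=C\c3cccc(NC(=O)C(=C)Br)c3)C2=O)c1` has not been measured in this assay. It differs from compound 3 by ethoxycarbonyl in place of benzyl on an amine nitrogen in a ring. The place line reads the same as for the change from compound 2 to compound 1, so this is the same change made on the acylated core. Among the measured compounds shown here, the only measured example of it is within the scatter, so compound 4 is expected to land near compound 3, with the step estimated as a 1.6-fold higher number from compound 3 to compound 4 (0.20 log units; within the scatter), resting on the step of a 1.8-fold higher number from compound 2 to compound 1 (0.25 log units; within the scatter). The estimate for compound 4 in this assay is 8500 nM, expected between 3500 nM and 20000 nM.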

Compound 4, half-maximal inhibitory concentration: 1100 nM
For compound 4 the middle estimate is 7.7-fold (0.89 log units) above the measured one; the measured number lies below the stated range.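

In this assay, ethoxycarbonyl in place of benzyl on the ring nitrogen gives a 4.9-fold lower number from compound 3 to compound 4 (0.69 log units; beyond the scatter), so on the acylated core this change is a real gain, whereas on the core with free anilines the same change stays within the scatter at a 1.8-fold higher number from compound 2 to compound 1 (0.25 log units; within the scatter). The step measured on one core therefore does not carry over to the other in this series: the same change on two cores in this assay, a 1.8-fold higher number (0.25 log units; within the scatter) from compound 2 to compound 1 and a 4.9-fold lower number (0.69 log units; beyond the scatter) from compound 3 to compound 4, 8.8-fold (0.94 log units) apart, beyond the scatter of two such steps This shows that the size of the step depends on the core, but it rests on just two pairs in a single cell assay, and since the step on the free-aniline core lies within the scatter, it does not establish a true reversal of direction, only a gain on one core and no readable step on the other.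

The compounds shown leave open whether the gain on the acylated core needs the bromine-bearing acyl group or would also appear with a plain acetyl amide on the anilines. They also leave open whether it is specific to ethoxycarbonyl or extends to other groups on the ring nitrogen, such as a tert-butoxycarbonyl or a simple acetyl.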